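A few compounds are considered here, and "the series" means these few. Any claim that something is new, unique, unknown or untested is made for them only; others in the source may bear on it.

Three close relatives of one shared core were tested in an assay on HEK293 cells for inhibition of transient receptor potential cation channel subfamily M member 2 (Homo sapiens), read by patch clamp, with a stated time of 60 s; a higher number here means a weaker inhibitor, a lower number a stronger inhibitor. Compound 1, with structure `Cc1cc(C)c2c(c1)C(=O)NC(c1c[nH]nc1-c1ccccc1)N2`, and compound 2, with structure `Cc1cccc2c1NC(c1c[nH]nc1-c1ccccc1)NC2=O`, both carry a phenylpyrazole on that core, yet neither has a number to show: compound 1 gives "not determined" (no result reported) and compound 2 gives "not determined" (no result reported). Only compound 3, with structure `Cc1cc(Cl)cc2c1NC(c1c[nH]nc1-c1ccccc1)NC2=O`, was actually measured, and in this assay compound 3 gives 5100 nM. That makes compound 3 the one fixed point among the three, with nothing to compare it against.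

The next compound, compound 4, has structure `Cc1cc(Br)cc2c1NC(c1c[nH]nc1-c1ccccc1)NC2=O`. It differs from compound 3 in a single spot: bromo in place of chloro on an aromatic carbon. Swapping one halogen for another of the same kind of size leaves the rest of the molecule untouched, so the step from one to the other is expected to be small. Among the compounds with values here, no measured pair in this set shows what such a swap does here, so the expectation rests on the change itself rather than on a seen step. The expected step from compound 3 to compound 4 in this assay is a 1.3-fold lower number from compound 3 to compound 4 (0.11 log units; within the scatter), which is within the usual scatter. For compound 4 the expected result in this assay is 4000 nM, with a likely range from 1500 nM to 12000 nM.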

Compound 4, half-maximal inhibitory concentration: 4600 nM
Estimate against measurement, compound 4: 1.2-fold (0.06 log units) below, within the range that was stated.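

The step for bromo in place of chloro on this aromatic carbon, meta to a methyl group, is a 1.1-fold lower number from compound 3 to compound 4 (0.04 log units; within the scatter) in this assay and gives the first direct view of a change at this position. On this evidence, the two halogens cannot be told apart here, so compound 3 and compound 4 stand at the same level as inhibitors. No measurement that could explain this result accompanies these values, so the reason for it remains unknown.

Within the data shown here, compound 1 and compound 2 have no number, so no steps involving them can be read, and with compound 2 carrying no halogen on this carbon, what either halogen adds compared with none stays open. Also open, from the compounds shown here alone, is whether the result would hold for a group of a different kind at the same place, such as an amine, a carboxylic acid, a methoxy group or a longer alkyl chain, since a swap between two halogens cannot show how far the position tolerates change.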